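Vasopressin V2 agonists: urea replacements on the benzylamine

The source may report more compounds than this note shows. Statements on the series, on what has been measured and on what is new or still open speak of the compounds shown alone.

Measured so far:
compound 1 `Cc1cc(C(=O)N2CCCCc3ccccc32)ccc1CNC(=O)Nc1c(F)cccc1F` — 2.1 nM
compound 2 `Cc1cc(C(=O)N2CCCCc3ccccc32)ccc1CNC(=O)NCC(=O)N1CCCC1` — 100 nM
compound 3 `Cc1cc(C(=O)N2CCCCc3ccccc32)ccc1CNC(=O)N1CCC[C@H]1C(=O)OC(C)(C)C` — 390 nM

Compound 3 stands at the highest number of the three in a functional assay on HEK293 cells for agonist activity at Vasopressin V2 receptor (Homo sapiens), read by a luciferase reporter and cAMP accumulation; on this read-out lower numbers stand for an effect already at smaller amounts and higher numbers for an effect only at larger amounts of compound. Its nearest neighbour is compound 2, reached by a 3.9-fold higher number from compound 2 to compound 3 (0.59 log units; beyond the scatter); the furthest gap is a 190-fold higher number from compound 1 to compound 3 (2.27 log units; beyond the scatter). Both steps away from the 2,6-difluorophenyl urea of compound 1 cost potency, with a 48-fold higher number from compound 1 to compound 2 (1.68 log units; beyond the scatter) the smaller of the two losses.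

Compound 4 `Cc1cc(C(=O)N2CCCCc3ccccc32)ccc1CNC(=O)N1CCC[C@@H]1C(=O)N(C)C` keeps the shared core and the pyrrolidine on the urea carbonyl; the change is 2-(dimethylcarbamoyl)pyrrolidin-1-yl in place of 2-(tert-butoxycarbonyl)pyrrolidin-1-yl on a carbonyl carbon. Among the compounds with values here, no measured pair alters this ester directly. The step that bears on it most closely is a 3.9-fold higher number from compound 2 to compound 3 (0.59 log units; beyond the scatter), since compound 2 also carries a pyrrolidine amide on its urea substituent and gives 100 nM, whereas the ester of compound 3 gives 390 nM. Moving compound 4 to a tertiary amide brings it nearer in kind to compound 2, so a modest shift toward a lower number is expected, of about a 2.0-fold lower number from compound 3 to compound 4 (0.29 log units; within the scatter), though a result within the scatter of compound 3 would not surprise. The estimate for compound 4 in this assay is 200 nM, expected to lie between 60 nM and 700 nM.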

Compound 4, half-maximal effective concentration: 380 nM
Estimate against measurement, compound 4: 1.9-fold (0.28 log units) below; low and high end bracket the measured number.
By their numbers in this assay, from the lowest: compound 1; then compound 2; then compounds 4 and 3 (each within the scatter of the next).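

In this assay, 2-(dimethylcarbamoyl)pyrrolidin-1-yl in place of 2-(tert-butoxycarbonyl)pyrrolidin-1-yl on the carbonyl carbon gives a 1.0-fold lower number from compound 3 to compound 4 (0.01 log units; within the scatter) and so leaves the read-out within the scatter, which means this position does not distinguish the dimethyl amide from the tert-butyl ester in the pair as drawn. The ester therefore does not account on its own for the gap to compound 2: a tertiary amide on the pyrrolidine still leaves a 3.8-fold higher number from compound 2 to compound 4 (0.58 log units; beyond the scatter) and, against the 2,6-difluorophenyl urea, a 180-fold higher number from compound 1 to compound 4 (2.26 log units; beyond the scatter) as well. The data at hand offer no measurement that explains these differences.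

From the compounds shown here alone, the structures of compound 3 and compound 4 are drawn with opposite configuration at the defined stereocentre, so the effect of the amide for ester change at a single configuration remains open, as does the effect of configuration itself. Also open, going by these compounds, is whether a carboxylic acid or a primary amide on the pyrrolidine, or an unsubstituted pyrrolidine on the carbonyl carbon, would read differently from the two substituted pyrrolidines.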